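This account rests on a few compounds, and the source may have more. Where it says the series, first, only, none or still open, it means among the compounds named here.

Compound 3 `CCC(=O)N(c1cccc(F)c1)C1CCCC1N(C)C` gives 0.6 mg/kg in a functional assay on the whole organism for antagonist activity, with Mus musculus as the target (on this read-out lower numbers stand for an effect already at smaller amounts and higher numbers for an effect only at larger amounts of compound), and sits far from compound 2 `CCC(=O)N(c1cccc(C)c1)C1CCCCC1N(C)C` at 15 mg/kg on this scale, a gap well beyond the usual scatter.

Compound 4 `CCC(=O)N(c1cccc(Br)c1)C1CCCC1N(C)C` keeps everything in compound 3 except one group: bromo takes the place of fluoro on an aromatic carbon of a six-membered aromatic ring of carbon only, meta to a large group bromo in place of fluoro on an aromatic carbon in counted terms.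

Among the compounds with values here, no measured pair shows this exact exchange, so the expectation rests on thin evidence. The closest guide is that compound 1 `CCC(=O)N(c1cccc(C)c1)C1CCCC1N(C)C` at 1 mg/kg; 1 mg/kg (2 entries) and compound 3 at 0.6 mg/kg carry different groups at this place and still lie within the scatter of each other. In this assay a step beyond the scatter is therefore not expected, although a slight drift toward a higher number is possible. The estimated step of a 1.7-fold higher number from compound 3 to compound 4 (0.22 log units; within the scatter) stays within the scatter. The estimate for compound 4 is 1 mg/kg with 0.3 mg/kg to 3.5 mg/kg as its expected range.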

Compound 4, dose for half-maximal effect: 0.1 mg/kg
Estimate against measurement, compound 4: 10-fold (1.00 log units) above; the measured number lies below the stated range.
By their numbers in this assay, from the lowest: compound 4; then compound 3; then compound 2.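

Bromo in place of fluoro gives a 6.0-fold lower number from compound 3 to compound 4 (0.78 log units; beyond the scatter) in this assay and so shows that the result at this aromatic carbon depends on which group sits there, a step beyond the usual scatter. The earlier comparison could not show this: compound 1, with a methyl group on this carbon, gives 1 mg/kg; 1 mg/kg (2 entries) and lies within the scatter of compound 3. Nothing available here explains why bromo and fluoro differ in this way.

The compounds shown leave open whether chloro, iodo or a nitrile on this carbon would give a number as low as that of compound 4. They also leave open whether bromo would bring a similar step on the core of compound 2, whose number is much higher.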